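Aryl change on the amide nitrogen of compound 1

The source may hold more compounds than are shown below. What is called first, only, known or untested is meant among the compounds shown, and "the series" means these compounds.

Compound 1 `Nc1ccccc1NC(=O)CCCNCC(=O)Nc1cccc(Cl)c1`: > 100000 nM (a limit)
Compound 2 `Nc1ccccc1NC(=O)c1ccc(NCC(=O)Nc2cccc([N+](=O)[O-])c2)cc1`: 52000 nM

In a functional assay on U-251 cells (Homo sapiens) for inhibition, read by MTT assay, with a stated time of 2 days (on this read-out lower numbers stand for stronger inhibition of growth and higher numbers for weaker inhibition of growth), compound 1 gives > 100000 nM, which is a limit and not a number. Compound 3 `COc1ccc(NC(=O)CNCCCC(=O)Nc2ccccc2N)cc1` differs from compound 1 in a single place: 4-methoxyphenyl in place of 3-chlorophenyl on an amide-type nitrogen. For the measured compounds named here, no measured pair shows this change, so any expectation for it is tentative. No shift beyond the usual scatter is expected in this assay, in either direction, and growth inhibition should stay weak. The expected change is an at least 1.1-fold lower number from compound 1 to compound 3 (0.07 log units; that floor lies within the scatter). The estimate for compound 3 is 85000 nM, with an expected range of 35000 nM to 200000 nM.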

Compound 3, concentration for total growth inhibition: > 100000 nM
Compound 3: a limit, no number; the forecaster's own chance of this, stated with the estimate: 60%; at least 1.1-fold (0.07 log units) between middle value and limit.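

For the compounds shown here, compound 3 reads > 100000 nM, a limit and not a number, as does compound 1, so no step between the two can be read. On these data alone, whether 4-methoxyphenyl in place of 3-chlorophenyl shifts growth inhibition at all stays open.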